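Swapping chloro for methoxy in a small antiproliferative series

The source may hold more compounds than are shown below. What is called first, only, known or untested is meant among the compounds shown, and "the series" means these compounds.

Measured so far in a functional assay on K562 cells (Homo sapiens) for antiproliferative activity, read by MTT assay, with a stated time of 72 h (a lower number here means a stronger inhibitor, a higher number a weaker inhibitor), as half-maximal inhibitory concentration:
- compound 1 `COc1cc(C(=O)c2sc3ccccc3c2-c2ccc(F)cc2)cc(OC)c1OC` gives 2100 nM
- compound 2 `COc1cc(C(=O)c2sc3ccccc3c2-c2ccc(Cl)cc2)cc(OC)c1OC` gives 4200 nM
- compound 3 `COc1cc(C(=O)c2sc3ccccc3c2-c2ccc(C)cc2)cc(OC)c1OC` gives 3500 nM

Compound 2 does not stand apart from the other two, since both of its steps lie within the scatter: a 2.0-fold higher number from compound 1 to compound 2 (0.30 log units; within the scatter) and a 1.2-fold lower number from compound 2 to compound 3 (0.08 log units; within the scatter) are the gaps that separate it from them. Compound 4 `COc1ccc(-c2c(C(=O)c3cc(OC)c(OC)c(OC)c3)sc3ccccc23)cc1` has methoxy in place of chloro on an aromatic carbon, so that 4-chlorophenyl becomes 4-methoxyphenyl. Among the measured compounds shown here, no measured compound carries methoxy there. The nearest evidence is the other changes at that same carbon, namely a 2.0-fold higher number from compound 1 to compound 2 (0.30 log units; within the scatter) and a 1.2-fold lower number from compound 2 to compound 3 (0.08 log units; within the scatter) and a 1.7-fold higher number from compound 1 to compound 3 (0.22 log units; within the scatter) and none of these leaves the scatter. In this assay no step beyond the scatter is therefore expected for this change, in either direction. The estimated change is a 1.4-fold lower number from compound 2 to compound 4 (0.15 log units; within the scatter) and it stays small. Compound 4 is expected at about 3000 nM as an estimate. Its estimated range runs from 1200 nM to 6500 nM and the measurement is still to come.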

Compound 4, half-maximal inhibitory concentration: 1700 nM
Estimate against measurement, compound 4: 1.8-fold (0.25 log units) above, and the stated range covers the measured number.
By their numbers in this assay, from the lowest: compounds 4, 1, 3 and 2 (each within the scatter of the next, the first and the last beyond it).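

In this assay, among the compounds shown here, the methoxy of compound 4 gives the first steps at this carbon that leave the scatter, both modest (a 2.5-fold lower number from compound 2 to compound 4 (0.39 log units; beyond the scatter); a 2.1-fold lower number from compound 3 to compound 4 (0.31 log units; beyond the scatter)). Among fluoro, chloro and methyl, every step had stayed within the scatter, so the earlier compounds gave no sign that a change here could move the number beyond it. Methoxy separates from chloro and methyl but not from fluoro (a 1.2-fold lower number from compound 1 to compound 4 (0.09 log units; within the scatter)), so compound 1 goes against any claim that methoxy alone sets itself apart at this position.

Nothing in the data available bears on why the number moves with this change. The compounds shown leave open whether a hydroxyl, an amine or a longer chain such as ethoxy at this carbon would follow methoxy or fall with chloro and methyl.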